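Swapping the Aromatic Amide Cap for a Fluorophenylethyl Chain

The compounds below may be only part of what the source reports. "The series", "measured", "known", "first", "only" and "open" are said of these compounds alone.

Compound 1 `Cc1ccc(C(=O)N[C@@H](C(=O)N2CCC(c3ccc(Cl)cc3)CC2)C(C)C)cc1`: 25 nM
Compound 2 `CC(C)[C@@H](NC(=O)c1nc2ccccc2s1)C(=O)N1CCC(c2ccc(Cl)cc2)CC1`: 18 nM

Of these two numbers in an assay on THP-1 cells for displacement of a labelled ligand from C-C chemokine receptor type 1 (Homo sapiens) (on this read-out lower numbers stand for stronger inhibition and higher numbers for weaker inhibition), compound 2 has the lower; the step of a 1.4-fold lower number from compound 1 to compound 2 (0.14 log units; within the scatter) lies within the scatter, so the two compounds cannot be ordered. Compound 3 `CC(C)[C@@H](NC(=O)CCc1ccc(F)cc1)C(=O)N1CCC(c2ccc(Cl)cc2)CC1` differs from compound 2 by 2-(4-fluorophenyl)ethyl in place of 1,3-benzothiazol-2-yl on a carbonyl carbon. For the measured compounds named here, the only measured step exchanges one aromatic cap for another; no step tests a chain in this place, so the data give little guidance. A modest weakening beyond the scatter is expected, the step of a 2.8-fold higher number from compound 2 to compound 3 (0.44 log units; beyond the scatter). For compound 3 the estimate is 50 nM, with a range from 12 nM to 250 nM.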

Compound 3, half-maximal inhibitory concentration: 70 nM
Beside the measured number, compound 3's estimate is 1.4-fold (0.15 log units) below it; the measured number falls inside the stated range.
By their numbers in this assay, from the lowest: compounds 2 and 1 (each within the scatter of the next); then compound 3.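

This place on the carbonyl carbon does respond to the group it carries: 2-(4-fluorophenyl)ethyl gives a 3.9-fold higher number from compound 2 to compound 3 (0.59 log units; beyond the scatter) and a 2.8-fold higher number from compound 1 to compound 3 (0.45 log units; beyond the scatter), whereas the earlier exchange of one aromatic cap for another could not be read. Among the three groups shown, the only one that holds its ring on an ethyl chain is the one that stands apart, though this single compound cannot separate the effect of the chain from that of the fluorine. No evidence is available to explain this weakening.

Still open, on these data alone, is whether a plain 2-phenylethyl group, without fluorine, or a longer chain such as 3-phenylpropyl would group with compound 3 or with compounds 1 and 2.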